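Replacing the indol-1-yl group of compound 3 on a saturated ring carbon

This account rests on a few compounds, and the source may have more. Where it says the series, first, only, none or still open, it means among the compounds named here.

Compound 3 `O=C1c2ccccc2CCCN1CCN1CCC(n2ccc3ccccc32)CC1` gives 2.75 nM in an assay on isolated protein for binding affinity to 5-hydroxytryptamine receptor 7 (Homo sapiens) (a lower number here means a stronger inhibitor, a higher number a weaker inhibitor), the second highest of the three numbers measured. Compound 2 `O=C(c1ccc(Cl)cc1)C1CCN(CCN2CCCc3ccccc3C2=O)CC1` gives 2.51 nM, and the two lie within the scatter (a 1.1-fold higher number from compound 2 to compound 3 (0.04 log units; within the scatter)). Compound 1 `O=C1c2ccccc2CCCN1CCN1CCC(Oc2ccc(Cl)cc2)CC1` gives 11.8 nM; the steps from it are a 4.7-fold lower number from compound 1 to compound 2 (0.67 log units; beyond the scatter) and a 4.3-fold lower number from compound 1 to compound 3 (0.63 log units; beyond the scatter). Compound 4 `O=C1c2ccccc2CCCN1CCN1CCC(n2nnc3ccccc32)CC1` differs from compound 3 in one place: a group of 9 heavy atoms (6 carbon, 3 nitrogen; one five-membered aromatic ring with 3 hetero atoms, one six-membered aromatic ring of carbon only) in place of a group of 9 heavy atoms (8 carbon, 1 nitrogen; one five-membered aromatic ring with 1 hetero atom, one six-membered aromatic ring of carbon only), on a saturated ring carbon. Within the data shown here, the steps that bear on this change are those on the same saturated ring carbon, a 4.3-fold lower number from compound 1 to compound 3 (0.63 log units; beyond the scatter) and a 1.1-fold higher number from compound 2 to compound 3 (0.04 log units; within the scatter); the group there matters modestly, while different groups can give numbers within the scatter. A step of a 1.8-fold higher number from compound 3 to compound 4 (0.26 log units; within the scatter) toward a somewhat higher number is expected for compound 4, in this assay. The estimate for compound 4 is 5 nM, with a range from 1.5 nM to 20 nM.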

Compound 4, inhibition constant: 14.1 nM
Compound 4: the middle estimate sits 2.8-fold (0.45 log units) below what was measured; low and high end bracket the measured number.
By their numbers in this assay, from the lowest: compounds 2 and 3 (each within the scatter of the next); then compounds 1 and 4 (each within the scatter of the next).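

On this saturated ring carbon, the heavy-atom count alone does not set the number: with 9 heavy atoms on both sides, changing the five-membered aromatic ring from 1 hetero atom to 3 hetero atoms gives a 5.1-fold higher number from compound 3 to compound 4 (0.71 log units; beyond the scatter). The step of a 5.6-fold higher number from compound 2 to compound 4 (0.75 log units; beyond the scatter) also lies beyond the scatter, while a 1.2-fold higher number from compound 1 to compound 4 (0.08 log units; within the scatter) lies within it, so compound 4 groups with the 4-chlorophenoxy compound rather than with the other two. Nothing available here accounts for these steps.

The compounds shown leave open which of the added ring nitrogens carries the step, which a benzimidazol-1-yl group on the same carbon would help separate. Going by these compounds, how an amine at this place would read also remains open.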